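From 4-methoxyphenyl to 2-bromophenyl on a carbonyl carbon

A few compounds are considered here, and "the series" means these few. Any claim that something is new, unique, unknown or untested is made for them only; others in the source may bear on it.

Measured so far in an ADME assay on HEK293 cells (Homo sapiens) for cytotoxicity, read by MTT assay, with a stated time of 72 h; on this read-out higher numbers stand for weaker inhibition and lower numbers for stronger inhibition:
Compound 1 `COc1ccc(C(=O)N2CCN(CC(=O)N3CCN(CCCc4c[nH]c5ccccc45)CC3)CC2)cc1` gives 156000 nM
Compound 2 `O=C(CN1CCN(C(=O)c2ccc(F)cc2)CC1)N1CCN(CCCc2c[nH]c3ccccc23)CC1` gives 141000 nM
Compound 3 `COc1ccc(C(=O)N2CCN(CC(=O)N3CCN(CCCc4c[nH]c5ccc(F)cc45)CC3)CC2)cc1` gives 141000 nM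

Compound 3 shows the same number as compound 2, and all three values lie within the scatter of one another. Compound 4 `O=C(CN1CCN(C(=O)c2ccccc2Br)CC1)N1CCN(CCCc2c[nH]c3ccc(F)cc23)CC1` departs from compound 3 at one place: 2-bromophenyl in place of 4-methoxyphenyl on a carbonyl carbon. Going by the values given here, no measured compound carries the 2-bromophenyl group, so the evidence is indirect. Compound 2 replaces methoxy with fluoro, with a 1.1-fold lower number from compound 1 to compound 2 (0.04 log units; within the scatter). Compound 3 adds fluoro in place of hydrogen, with a 1.1-fold lower number from compound 1 to compound 3 (0.04 log units; within the scatter). Neither step leaves the scatter, so no step beyond the scatter is expected in this assay. The estimate means a 1.1-fold lower number from compound 3 to compound 4 (0.04 log units; within the scatter), an expected step within the scatter. For compound 4 the expected value is 130000 nM, with an estimated range from 70000 nM to 220000 nM.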

Compound 4, half-maximal inhibitory concentration: 77100 nM
Compound 4: the middle estimate sits 1.7-fold (0.23 log units) above what was measured; measured number inside the range.
By their numbers in this assay, from the lowest: compounds 4, 2, 3 and 1 (each within the scatter of the next, the first and the last beyond it).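

In this assay, replacing the whole 4-methoxyphenyl group with 2-bromophenyl on a carbonyl carbon gives a 1.8-fold lower number from compound 3 to compound 4 (0.26 log units; within the scatter). This position therefore tolerates a change of both substituent and its place on the phenyl ring without leaving the scatter, whereas the earlier step at this site, in compound 2, exchanged only methoxy for fluoro. Nothing available bears on the cause of this step.

The compounds shown leave open whether an amine or a carboxylic acid on this phenyl ring would also stay within the scatter. Going by these compounds, how 2-bromophenyl reads on the core of compound 1, without the fluoro, also remains open.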